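The source may report more compounds than this note shows. Statements on the series, on what has been measured and on what is new or still open speak of the compounds shown alone.

Measured so far in a functional assay on DU-145 cells (Homo sapiens) for cytotoxicity, read by MTT assay; on this read-out higher numbers stand for weaker inhibition and lower numbers for stronger inhibition:
- compound 1, `CC(=O)OCCO[C@H](CC=C(C)C)C1=CC(=O)c2c(O)ccc(O)c2C1=O`: 15500 nM
- compound 2, `CCCCCCC(C)(O)CC(=O)O[C@H](CC=C(C)C)C1=CC(=O)c2c(O)ccc(O)c2C1=O`: a limit only, > 100000 nM

Compound 2 stands at the weaker end of the numbers shown, and its value is a limit of the assay rather than a number: the limit of > 100000 nM in this assay, at which 1 of the 2 values shown sits. Compound 3, `CCC(O)(CC)CC(=O)O[C@H](CC=C(C)C)C1=CC(=O)c2c(O)ccc(O)c2C1=O`, keeps the core of compound 2 and differs from it in one place: 1-ethyl-1-hydroxypropyl in place of 1-hydroxy-1-methylheptyl on a saturated chain carbon bound to a carbonyl carbon. For the measured compounds named here, no step between two measured compounds is available here, so the size of this change has to be judged from the two values alone. Compound 1, which carries a different and shorter group at that place, gives 15500 nM in this assay. On that basis the step from compound 2 to compound 3 is expected to run toward stronger inhibition, by roughly an at least 1.6-fold lower number from compound 2 to compound 3 (0.22 log units; that floor lies within the scatter). Compound 3 is therefore estimated at 60000 nM, with a range from 20000 nM to 200000 nM, and a real chance that this assay again reports only a limit.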

Compound 3, half-maximal inhibitory concentration: 67000 nM
The estimate for compound 3 lay 1.1-fold (0.05 log units) below the measured number, and the stated range covers the measured number.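

In this assay compound 2 has only a limit, not a number: the limit of > 100000 nM in this assay, at which 1 of the 3 values shown sits. Putting 1-ethyl-1-hydroxypropyl in place of 1-hydroxy-1-methylheptyl gives an at least 1.4-fold lower number from compound 2 to compound 3 (0.17 log units; that floor lies within the scatter), so the shorter group brings the value within a measurable range, but the step has only a floor and its true size cannot be read. For the compounds shown here, the change to (2-ethyl-2-hydroxybutyl)carbonyl in place of 2-acetoxyethyl, on an oxygen on a saturated carbon, gives a 4.3-fold higher number from compound 1 to compound 3 (0.64 log units; beyond the scatter), a modest loss of inhibition and the only step here with a full size.

From the compounds shown here alone, what an amine or a carboxylic acid in place of the hydroxyl on this chain would do remains open. So does whether a still shorter hydroxy-bearing group would carry inhibition further in the same direction.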